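From fluoro to methyl on the shared core

This account rests on a few compounds, and the source may have more. Where it says the series, first, only, none or still open, it means among the compounds named here.

Within the data shown here, in a functional assay on HeLa cells (Homo sapiens) for antiproliferative activity, read by MTT assay, with a stated time of 48 h (on this read-out higher numbers stand for weaker inhibition and lower numbers for stronger inhibition), compound 1 `Fc1ccc(-c2nn(-c3ccccc3)cc2-c2nc3cc(F)ccc3[nH]2)cc1` gives 1570 nM and compound 2 `Fc1ccc2[nH]c(-c3cn(-c4ccccc4)nc3-c3ccc(Cl)cc3)nc2c1` gives 2770 nM, so compound 2 stands within the scatter of its only neighbour. Among the measured compounds shown here, the single measured step, a 1.8-fold higher number from compound 1 to compound 2 (0.25 log units; within the scatter), is chloro in place of fluoro on an aromatic carbon. Compound 3 `Cc1ccc2[nH]c(-c3cn(-c4ccccc4)nc3-c3ccc(Cl)cc3)nc2c1` differs from compound 2 in one place: methyl in place of fluoro on an aromatic carbon. For the measured compounds named here, the measured step concerns another aromatic carbon and another exchange, so it bears only loosely, and no measured pair tests a methyl group. Going by the values given here, with only that small step, a 1.8-fold higher number from compound 1 to compound 2 (0.25 log units; within the scatter), as a guide, no shift beyond the scatter is expected in this assay. The expected change is a 1.0-fold higher number from compound 2 to compound 3 (0.00 log units; within the scatter), in neither clear direction. For compound 3 the estimate is 2800 nM, with an expected range of 1200 nM to 6500 nM.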

Compound 3, half-maximal inhibitory concentration: 5360 nM
Compound 3: middle estimate off by 1.9-fold (0.28 log units), on the low side; low and high end bracket the measured number.
By their numbers in this assay, from the lowest: compounds 1, 2 and 3 (each within the scatter of the next, the first and the last beyond it).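

In this assay, among these compounds, the exchange of fluoro for methyl on the six-membered aromatic ring of the fused system gives a 1.9-fold higher number from compound 2 to compound 3 (0.29 log units; within the scatter) and is the first measured change at this aromatic carbon, as the earlier step concerned another one. Fluoro and methyl are therefore not told apart at this position in this assay, although the two groups share only their count of one heavy atom, and this single pair supports no wider pattern. Nothing at hand explains this result or links it to any property of either group.

The compounds shown leave open whether an amine, a methoxy group or a carboxylic acid on this aromatic carbon would shift the number beyond the scatter. They also leave open whether methyl here would give the same reading with fluoro in place of chloro at the other changed aromatic carbon.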